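From Methyl to Ethyl: Compound 3 to Compound 4

A few compounds are considered here, and "the series" means these few. Any claim that something is new, unique, unknown or untested is made for them only; others in the source may bear on it.

In an ADME assay on microsomes from liver (Rattus norvegicus, strain Sprague-Dawley) for metabolic stability, read by LC-MS, with a stated time of 15 min, tested at 20 uM (on this read-out lower numbers stand for a less stable compound and higher numbers for a more stable compound), compound 3 `Cc1ccccc1OC(=O)c1coc(-c2ccccc2)n1` gives 13.4%, compound 1 `CCC(=O)c1ccccc1OC(=O)c1coc(-c2ccccc2)n1` gives 8.7% and compound 2 `CCC(C)c1ccccc1OC(=O)c1coc(-c2ccccc2)n1` gives 8.3%, so all three lie within the scatter of one another. Compound 4 `CCc1ccccc1OC(=O)c1coc(-c2ccccc2)n1` has not been measured. It differs from compound 3 by methyl in place of hydrogen on a saturated chain carbon bound to an aromatic carbon, with methyl in place of hydrogen on a saturated chain carbon bound to an aromatic carbon, which turns methyl into ethyl. Within the data shown here, two measured steps bear on this, both changing a group on an aromatic carbon: a number 5.1 percentage points higher from compound 2 to compound 3 (within the scatter) and a number 4.7 percentage points higher from compound 1 to compound 3 (within the scatter). Neither exceeds the scatter, so no real shift is expected in this assay. The estimated step is a number 2.4 percentage points lower from compound 3 to compound 4 (within the scatter). The expected value for compound 4 is 11%, within an estimated range of 5% to 20%.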

Compound 4, percent of the compound remaining: 8.5%
Compound 4: the middle estimate sits 2.5 percentage points above what was measured; the measured number falls inside the stated range.
By their numbers in this assay, from the lowest: compounds 2, 4, 1 and 3 (each within the scatter of the next).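

In this assay, adding methyl on a saturated chain carbon bound to an aromatic carbon, which turns methyl into ethyl, gives a number 4.9 percentage points lower from compound 3 to compound 4 (within the scatter) and so does not shift stability measurably. Ethyl also reads the same as the two larger groups, with a number 0.2 percentage points higher from compound 2 to compound 4 (within the scatter) and a number 0.2 percentage points lower from compound 1 to compound 4 (within the scatter) showing that sec-butyl, propanoyl, ethyl and methyl cannot be told apart here. Nothing available explains why these compounds read alike.

Still open, on these data alone, is whether an amine, a carboxylic acid or a longer chain in this place would move the number beyond the scatter.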